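Swapping bromo for methoxy on the hydroxybenzamide core

A few compounds are considered here, and "the series" means these few. Any claim that something is new, unique, unknown or untested is made for them only; others in the source may bear on it.

Measured compounds:
Compound 1, `Cc1ccc(C(=O)Nc2ccc(C#N)cc2)c(O)c1`, gives 2420 nM.
Compound 2, `N#Cc1ccc(NC(=O)c2ccc(-c3cccnc3)cc2O)cc1`, gives 6660 nM.
Compound 3, `N#Cc1ccc(NC(=O)c2ccc(Br)cc2O)cc1`, gives 1210 nM.

These three share one core and differ only in the group on one aromatic carbon. In a functional assay on HL-60 cells (Homo sapiens) for cytotoxicity, read by luminescence and CellTiter-Glo, with a stated time of 3 days (on this read-out lower numbers stand for stronger inhibition and higher numbers for weaker inhibition), compound 3 gives the lowest number of the three: the step of a 2.0-fold lower number from compound 1 to compound 3 (0.30 log units; within the scatter) stays within the scatter, while the step of a 5.5-fold lower number from compound 2 to compound 3 (0.74 log units; beyond the scatter) lies beyond it.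

Compound 4, `COc1ccc(C(=O)Nc2ccc(C#N)cc2)c(O)c1`, has not been measured. It differs from compound 3 as follows: methoxy in place of bromo on an aromatic carbon. The most relevant measured steps both replace a small group at this same carbon. The step of a 2.0-fold lower number from compound 1 to compound 3 (0.30 log units; within the scatter) stays within the scatter, whereas a 2.8-fold higher number from compound 1 to compound 2 (0.44 log units; beyond the scatter), where a ring enters, moves the number clearly upward. Methoxy brings no ring, so a step of roughly a 2.1-fold higher number from compound 3 to compound 4 (0.32 log units; beyond the scatter) is expected for compound 4, small and toward a higher number. Compound 4 is therefore estimated at 2500 nM, with a range from 1000 nM to 6000 nM.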

Compound 4, half-maximal inhibitory concentration: 5470 nM
For compound 4 the middle estimate is 2.2-fold (0.34 log units) below the measured one; the range from low to high includes it.
By their numbers in this assay, from the lowest: compounds 3 and 1 (each within the scatter of the next); then compounds 4 and 2 (each within the scatter of the next).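

Until now, only the pyridin-3-yl ring of compound 2 had clearly raised the number at this position, but in this assay methoxy, which brings no ring, does so too, with a 4.5-fold higher number from compound 3 to compound 4 (0.66 log units; beyond the scatter) and a 2.3-fold higher number from compound 1 to compound 4 (0.35 log units; beyond the scatter) as the two steps. Methoxy also lands level with that ring, at a 1.2-fold lower number from compound 2 to compound 4 (0.09 log units; within the scatter) within the usual scatter, so among these compounds a ring is not needed for the higher number. Nothing available gives a reason for this shift.

From the compounds shown here alone, whether an amine, a carboxylic acid or a longer chain such as ethoxy at this carbon would sit with methyl and bromo or with methoxy and pyridin-3-yl stays open. Going by these compounds, whether the same order would hold on other cells also stays open.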